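Methoxy in place of methylsulfonyl on a shared core

The compounds below may be only part of what the source reports. "The series", "measured", "known", "first", "only" and "open" are said of these compounds alone.

Compound 1 `c1ccc(Sc2nn3cc(-c4cc5ccccc5o4)nc3s2)cc1`: 1900 nM
Compound 2 `CS(=O)(=O)c1nn2cc(-c3cc4ccccc4o3)nc2s1`: 820 nM

Compound 2 holds the lowest of the two numbers in a functional assay on HEK293 cells for antagonist activity at proteinase-activated receptor 4 (Homo sapiens), read by FLIPR and calcium flux, with a stated time of 30 min (on this read-out lower numbers stand for stronger inhibition and higher numbers for weaker inhibition), with compound 1 as its nearest neighbour. For the measured compounds named here, the single measured step, a 2.3-fold lower number from compound 1 to compound 2 (0.36 log units; beyond the scatter), is modest. Compound 3 `COc1nn2cc(-c3cc4ccccc4o3)nc2s1` carries the change (methoxy in place of methylsulfonyl on an aromatic carbon). Going by the values given here, no measured step exchanges methylsulfonyl for methoxy, so that one step is only an indirect guide. The expectation for compound 3 is a number near that of compound 2, without a shift beyond the scatter: a 1.5-fold higher number from compound 2 to compound 3 (0.17 log units; within the scatter). Compound 3 is therefore estimated at 1200 nM, within 400 nM to 3600 nM.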

Compound 3, half-maximal inhibitory concentration: 4 nM
The estimate for compound 3 lay 300-fold (2.48 log units) above the measured number; measured number below the stated range.
By their numbers in this assay, from the lowest: compound 3; then compound 2; then compound 1.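

In this assay, this position on the shared core proves far more sensitive than the modest earlier step suggested: methoxy gives a 210-fold lower number from compound 2 to compound 3 (2.31 log units; beyond the scatter), and replacing phenylsulfanyl with it gives a 480-fold lower number from compound 1 to compound 3 (2.68 log units; beyond the scatter). The group on this aromatic carbon can therefore shift the number greatly, and methoxy has the lowest number of the three. No evidence here explains the size of this change. Still open, from the compounds shown here alone, is whether ethoxy or a longer chain on the oxygen keeps this strength. An amine at the same carbon is also untested among the compounds shown.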